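Cytotoxicity notes: a nitro group on compound 2

The source may report more compounds than this note shows. Statements on the series, on what has been measured and on what is new or still open speak of the compounds shown alone.

Compound 1 `O=[N+]([O-])c1ccc(-c2nc3cc(C(F)(F)F)ccc3[nH]2)cc1` in an ADME assay on MT4 cells (Homo sapiens) for cytotoxicity, read by MTT assay, with a stated time of 96 h (a higher number here means that more compound is tolerated, a lower number that less compound is tolerated), gives 6000 nM
Compound 2 `CC(=O)Nc1ccc(-c2nc3ccccc3[nH]2)cc1` in this assay gives 100000 nM

Compound 2 stands highest of the two numbers in this assay, and its gap to compound 1 lies beyond the scatter. The two compounds differ in more than one place, so no single change can be read from that gap.

Compound 3 `CC(=O)Nc1ccc(-c2nc3cc([N+](=O)[O-])ccc3[nH]2)cc1` has nitro in place of hydrogen on an aromatic carbon of compound 2 (nitro in place of hydrogen on an aromatic carbon). Among the measured compounds shown here, no measured pair isolates this change. For the measured compounds named here, the only guide is compound 1 (6000 nM), which also carries a nitro group, though in a different place. A downward step beyond the scatter is therefore expected in this assay (estimated as a 3.3-fold lower number from compound 2 to compound 3 (0.52 log units; beyond the scatter)), smaller than the gap between the two measured compounds. Compound 3 is estimated at 30000 nM (expected range 8000 nM to 100000 nM).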

Compound 3, half-maximal cytotoxic concentration: > 100000 nM
Compound 3: no number, only a limit; the forecaster's own chance of this, stated with the estimate: 25%; middle value at least 3.3-fold (0.52 log units) from the limit.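

Compound 3 gives > 100000 nM as a limit of the assay and not a number. This is the only single-place step shown in the series: nitro in place of hydrogen, on an aromatic carbon of a six-membered aromatic ring of carbon only, gives a number no lower from compound 2 to compound 3 (the limit leaves the size open) in this assay, so at this place the nitro group brings no loss of tolerance. The size of the step cannot be read, and the reading stops at the top of the range: the limit of > 100000 nM in this assay, at which 1 of the 3 values shown sits.

Going by these compounds, how far the true number of compound 3 lies past that limit stays open, so any rise over compound 2 remains unsized. Also open, on these data alone, is whether an amine or a carboxylic acid on the same aromatic carbon would keep the number this high.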